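A few compounds are considered here, and "the series" means these few. Any claim that something is new, unique, unknown or untested is made for them only; others in the source may bear on it.

Measured in a functional assay on MGC-803 cells (Homo sapiens) for antiproliferative activity, read by MTT assay, with a stated time of 72 h; on this read-out lower numbers stand for stronger inhibition and higher numbers for weaker inhibition:
Compound 1 `CCCSc1nc(N/N=C(\C)c2ccc(O)cc2)c2nnn(Cc3ccccc3)c2n1`: 16700 nM
Compound 2 `CCCSc1nc(N/N=C/c2ccccc2)c2nnn(Cc3ccccc3)c2n1`: > 64000 nM (a limit)

Compound 2 sits at > 64000 nM, which is a limit of the assay and not a number.

Compound 3 `CCCSc1nc(N/N=C(\C)c2ccc(Br)cc2)c2nnn(Cc3ccccc3)c2n1` changes compound 2 as follows: a group of 10 heavy atoms (8 carbon, 1 nitrogen, 1 bromine; one six-membered aromatic ring of carbon only) in place of a group of 8 heavy atoms (7 carbon, 1 nitrogen; one six-membered aromatic ring of carbon only), on a nitrogen on an aromatic ring. Within the data shown here, the one measured step that bears on this is an at least 3.8-fold higher number from compound 1 to compound 2 (0.58 log units; beyond the scatter). In that step the group of 8 heavy atoms replaced a group of 10 heavy atoms, and the present change runs the opposite way, with bromine where the larger group of compound 1 held oxygen. The data do not show how bromine compares with oxygen here.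

The expected change is an at least 2.9-fold lower number from compound 2 to compound 3 (0.46 log units; beyond the scatter), towards a lower number and of roughly the size of that measured step, though another reading at the limit remains possible. For compound 3 the estimate is 22000 nM, with an expected range of 6000 nM to 64000 nM.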

Compound 3, half-maximal inhibitory concentration: 6020 nM
For compound 3 the middle estimate is 3.7-fold (0.56 log units) above the measured one, within the range that was stated.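

In this assay, bromo in place of hydroxy on an aromatic carbon gives a 2.8-fold lower number from compound 1 to compound 3 (0.44 log units; beyond the scatter), so exchanging this one substituent, with the rest of the structure held constant, moves the number beyond the scatter. The wider exchange of the whole group on the nitrogen gives an at least 10-fold lower number from compound 2 to compound 3 (1.02 log units; beyond the scatter), which is a bound and not an exact size, yet it shows that this position can carry a large difference in the read-out. Compound 2 stands at a limit and not at a number: the limit of > 64000 nM in this assay, at which 1 of the 3 values shown sits.

The wider exchange adds the bromine and a further carbon together, so the share of each in that step stays unresolved. Also open, as far as these compounds go, is how an amine, a carboxylic acid or a chloro group would compare with bromo in the same place.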